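The compounds below may be only part of what the source reports. "The series", "measured", "known", "first", "only" and "open" are said of these compounds alone.

Compound 1 `COc1ccc(-c2cn3ccnc3c(-c3ccc4ncn(C5CCCCC5)c4c3)n2)cc1` gives 65.2% in a functional assay on UACC-62 cells (Homo sapiens) for inhibition, read by sulforhodamine B assay, with a stated time of 48 h, tested at 10 uM; a higher number here means more inhibition at the concentration tested (going by the name of the read-out), a lower number less inhibition.
Compound 2 `c1cn2cc(-c3ccsc3)nc(-c3ccc4ncn(C5CCCCC5)c4c3)c2n1` gives 18.4%.
Compound 3 `COc1ccccc1-c1cn2ccnc2c(-c2ccc3ncn(C4CCCCC4)c3c2)n1` gives 25.1%.

Compound 3 stands second highest of the three numbers: its nearest neighbour is compound 2, the pair separated only by a number 6.7 percentage points higher from compound 2 to compound 3 (within the scatter), while compound 1 lies well above it, by a number 40.1 percentage points lower from compound 1 to compound 3 (beyond the scatter). Compound 4 `FC(F)(F)c1cccc(-c2cn3ccnc3c(-c3ccc4ncn(C5CCCCC5)c4c3)n2)c1` follows from compound 3 by the change (3-(trifluoromethyl)phenyl in place of 2-methoxyphenyl on an aromatic carbon). Two measured steps exchange the same aryl group on the shared core and so bear on this one: a number 40.1 percentage points lower from compound 1 to compound 3 (beyond the scatter) was large, whereas a number 6.7 percentage points higher from compound 2 to compound 3 (within the scatter) stayed within the scatter. For the measured compounds named here, no measured step introduces a trifluoromethyl-bearing ring, so the direction for compound 4 is open, and only a modest change is expected in this assay. Compound 4 is therefore estimated at 35%, within 10% to 65%, an expected step of a number 9.9 percentage points higher from compound 3 to compound 4 (within the scatter).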

Compound 4, a percentage reported as inhibition, at one concentration (the size of the read-out at that concentration, not a potency): 4.33%
For compound 4 the middle estimate is 30.7 percentage points above the measured one; the measured number lies below the stated range.
By their numbers in this assay, from the lowest: compound 4; then compounds 2 and 3 (each within the scatter of the next); then compound 1.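

In this assay, this position now separates groups beyond the scatter even at the low end: 3-(trifluoromethyl)phenyl falls under both 2-methoxyphenyl (a number 20.8 percentage points lower from compound 3 to compound 4 (beyond the scatter)) and thiophen-3-yl (a number 14.1 percentage points lower from compound 2 to compound 4 (beyond the scatter)), two groups that stayed within the scatter of each other. The gap to 4-methoxyphenyl widens as well (a number 60.9 percentage points lower from compound 1 to compound 4 (beyond the scatter)), leaving that group above all three replacements. Nothing measured here explains this order.

Open, going by these compounds, is how 3-methoxyphenyl would read, which would separate the methoxy group from its place on the ring. Also open, on these data alone, is how a phenyl ring carrying an amine or a carboxylic acid would read at this position.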